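A few compounds are considered here, and "the series" means these few. Any claim that something is new, unique, unknown or untested is made for them only; others in the source may bear on it.

Measured so far:
compound 1 `Nc1ncnc2c1ncn2/C=C1/C[C@@H]1[C@@H](O)CO` — 55000 nM
compound 2 `Nc1nc2c(ncn2/C=C2/CC2(CO)CO)c(=O)[nH]1` — 46000 nM
compound 3 `Nc1nc2c(ncn2/C=C2\C[C@H]2[C@H](O)CO)c(=O)[nH]1` — 86600 nM

In an ADME assay on Akata cells (Homo sapiens) for cytotoxicity (a higher number here means that more compound is tolerated, a lower number that less compound is tolerated), these three compounds give numbers that all lie within the usual scatter of one another, so none can be called better or worse tolerated than the others; compound 1 sits among them with no separation from either neighbour. Compound 4 `Nc1ncnc2c1ncn2/C=C1\C[C@H]1[C@@H](O)CO` is the next compound to be tested in this assay. Compared with compound 1, (the two compounds have the same atoms and bonds and differ only in configuration as drawn: 2 of 3 stereo elements differ; a stereocentre at a saturated ring carbon is drawn S in compound 1 and R in compound 4; a double bond is drawn Z in compound 1 and E in compound 4). Going by the values given here, no step between measured compounds with such a change is available, so the expectation rests on how little the tolerated concentrations differ across compounds 1, 2 and 3. The step from compound 1 to compound 4 is expected to be no change at the digits printed from compound 1 to compound 4 (within the scatter), nothing beyond the scatter. Compound 4 is therefore estimated at 55000 nM, within 25000 nM to 120000 nM.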

Compound 4, half-maximal cytotoxic concentration: 73000 nM
Beside the measured number, compound 4's estimate is 1.3-fold (0.12 log units) below it; the range from low to high includes it.
By their numbers in this assay, from the lowest: compounds 2, 1, 4 and 3 (each within the scatter of the next).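

In this assay, altering the drawn configuration at a saturated ring carbon and at the double bond together gives a 1.3-fold higher number from compound 1 to compound 4 (0.12 log units; within the scatter). This is the first pair in which nothing else varies, so the tolerated concentration can be read against shape as drawn alone, and here that shape makes no separable difference: the fact that compounds 1 and 4 differ only in the configuration as drawn

From the compounds shown here alone, both elements changed at once, so the effect of each alone stays unknown, and opposite effects could cancel. Going by these compounds, whether a carboxylic acid in place of a hydroxyl group would separate from these compounds also remains open.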